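The source may hold more compounds than are shown below. What is called first, only, known or untested is meant among the compounds shown, and "the series" means these compounds.

Measured compounds:
compound 1 `COCCNC(=O)Cn1sc2ccccc2c1=O` gives 45.1% in an assay on isolated protein for inhibition of histone acetyltransferase p300 (Homo sapiens), read by fluorescence, with a stated time of 10 min, tested at 50 uM; a higher number here means more inhibition at the concentration tested (going by the name of the read-out), a lower number less inhibition
compound 2 `O=C(Cn1sc2ccccc2c1=O)Nc1nccs1` gives 57.4% in this assay

Going by the values given here, of the two measured compounds, compound 2 stands highest in this assay; its only neighbour, compound 1, lies lower by a step beyond the scatter. Compound 3 `CC(C)CNC(=O)Cn1sc2ccccc2c1=O` is not yet measured and differs from compound 2 in one place: isobutyl in place of 1,3-thiazol-2-yl on an amide-type nitrogen. Among the compounds with values here, the single measured step that bears on this change is a number 12.3 percentage points higher from compound 1 to compound 2 (beyond the scatter), in which a five-membered aromatic ring took the place of a chain on the same amide-type nitrogen. Compound 3 makes a change of the reverse kind, putting a chain with no ring and no hydrogen-bond acceptors back in place of the ring. A step of comparable size in the downward direction is therefore expected in this assay, which would bring compound 3 close to compound 1. For compound 3 the expected value is 45%, with a range from 30% to 60%. The estimate for compound 3 means an expected step of a number 12.4 percentage points lower from compound 2 to compound 3 (beyond the scatter).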

Compound 3, a percentage reported as inhibition, at one concentration (the size of the read-out at that concentration, not a potency): 54.6%
For compound 3 the middle estimate is 9.6 percentage points below the measured one; low and high end bracket the measured number.
By their numbers in this assay, from the lowest: compounds 1, 3 and 2 (each within the scatter of the next, the first and the last beyond it).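

In this assay, replacing 1,3-thiazol-2-yl with isobutyl on the amide-type nitrogen gives a number 2.8 percentage points lower from compound 2 to compound 3 (within the scatter), so a five-membered aromatic ring with hydrogen-bond acceptors is not needed at this position to reach this level of inhibition. Comparing the two chains gives a number 9.5 percentage points higher from compound 1 to compound 3 (within the scatter), so isobutyl and 2-methoxyethyl cannot be told apart here, and only compound 1 and compound 2 lie apart by more than the scatter. Nothing measured here explains why the numbers fall this way.

As far as these compounds go, whether a phenyl ring, a carboxylic acid or a longer chain on this nitrogen would shift the number beyond the scatter remains open. Each value also comes from a single concentration, so how potency differs among these compounds is unknown.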